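The source may report more compounds than this note shows. Statements on the series, on what has been measured and on what is new or still open speak of the compounds shown alone.

Of the compounds shown here, two share one core and have been tested in a functional assay on SNB-19 cells (Homo sapiens) for inhibition, read by sulforhodamine B assay, with a stated time of 48 h, tested at 10 uM; a lower number here means a stronger effect, a higher number a weaker effect of the compound at the concentration tested. Compound 1 `COc1cc(Cl)cc(-c2nn(-c3cccc(NC(=O)c4cccc(C(F)(F)F)c4)c3)cc2-c2ccncc2)c1` gives 82.2% in this assay. Compound 2 `O=C(Nc1cccc(-n2cc(-c3ccncc3)c(-c3cc(O)cc(Cl)c3)n2)c1)c1cc(C(F)(F)F)cc(C(F)(F)F)c1` gives 63.1% in this assay, the lowest of the two numbers, with compound 1 standing higher by a gap beyond the usual scatter; compound 1 and compound 2 differ in more than one place, so their two values are shown here without a single change to account for the gap.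

Compound 3 `COc1cc(Cl)cc(-c2nn(-c3cccc(NC(=O)c4cc(C(F)(F)F)cc(C(F)(F)F)c4)c3)cc2-c2ccncc2)c1` has not yet been measured. It differs from compound 2 in one place: methyl in place of hydrogen on an oxygen on an aromatic ring. Among the measured compounds shown here, no single-change step of this kind has been measured among the compounds at hand, so the direction of the effect is open. Compound 3 is expected to land near 68% in this assay, within 50% to 86%. The expected step of a number 4.9 percentage points higher from compound 2 to compound 3 (within the scatter) is a modest rise, not clearly beyond the scatter.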

Compound 3, a percentage reported as activity, at one concentration (the size of the read-out at that concentration, not a potency): 86.4%
Estimate against measurement, compound 3: 18.4 percentage points below, and the stated range ends below it.
By their numbers in this assay, from the lowest: compound 2; then compounds 1 and 3 (each within the scatter of the next).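

In this assay, going from hydroxy to methoxy on the aromatic ring gives a number 23.3 percentage points higher from compound 2 to compound 3 (beyond the scatter), so at this oxygen the methyl goes with a weaker effect at the concentration tested, and the hydrogen with a stronger one. The other single change, trifluoromethyl in place of hydrogen on an aromatic carbon, gives a number 4.2 percentage points higher from compound 1 to compound 3 (within the scatter), so with methoxy in place this added group brings no clear change. Nothing measured here gives a reason for either step.

The compounds shown leave open whether the added trifluoromethyl would also make no clear difference with hydroxy in place of methoxy. They also leave open how an amine or an ethoxy group at this position would compare with hydroxy and methoxy.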